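The compounds below may be only part of what the source reports. "The series", "measured", "known", "first", "only" and "open" are said of these compounds alone.

In an ADME assay for permeability, using PAMPA, with a stated time of 30 min, at pH 7.4 (on this read-out lower numbers stand for lower permeability and higher numbers for higher permeability), compound 1 `COc1cccc(Oc2ccc3c(NCCCNCc4cccc(OC)c4O)ccnc3c2)c1` gives 317 10^-6 cm/s and compound 2 `COc1cccc(CNCCCNc2ccnc3cc(Oc4ccccc4)ccc23)c1O` gives 317 10^-6 cm/s. Compound 3 `COc1cccc(CNCCCNc2ccnc3cc(Cc4ccc(F)cc4)ccc23)c1O` gives 23 10^-6 cm/s, the lowest of the three values, set apart by a 14-fold lower number from compound 1 to compound 3 (1.14 log units; beyond the scatter) and by a 14-fold lower number from compound 2 to compound 3 (1.14 log units; beyond the scatter). Compound 4 `COc1ccc(-c2ccc3c(NCCCNCc4cccc(OC)c4O)ccnc3c2)cc1` differs from compound 3 in one place: 4-methoxyphenyl in place of 4-fluorobenzyl on an aromatic carbon. The two steps that bear on this change are the ones leading into compound 3, both large and both downward when 4-fluorobenzyl entered in place of phenoxy or 3-methoxyphenoxy. Compound 4 leaves 4-fluorobenzyl again, this time for 4-methoxyphenyl rather than for either of those groups, so a rise in this assay is expected, likely smaller than those steps. Compound 4 is therefore expected to give 120 10^-6 cm/s, within 40 10^-6 cm/s to 350 10^-6 cm/s, a step of a 5.2-fold higher number from compound 3 to compound 4 (0.72 log units; beyond the scatter).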

Compound 4, apparent permeability: 237 10^-6 cm/s
The estimate for compound 4 lay 2.0-fold (0.30 log units) below the measured number; low and high end bracket the measured number.
By their numbers in this assay, from the lowest: compound 3; then compounds 4, 1 and 2 (each within the scatter of the next).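

In this assay, 4-methoxyphenyl in place of 4-fluorobenzyl gives a 10-fold higher number from compound 3 to compound 4 (1.01 log units; beyond the scatter), so the low number does not extend to every aryl-bearing group at this position. Among these compounds, the new group also matches the two ether-linked groups, with a 1.3-fold lower number from compound 2 to compound 4 (0.13 log units; within the scatter) and a 1.3-fold lower number from compound 1 to compound 4 (0.13 log units; within the scatter), which leaves 4-fluorobenzyl as the only one of the four groups set apart. The compounds leave open whether plain benzyl or 4-fluorophenyl would give a low or a high number, and so which part of 4-fluorobenzyl goes with the drop. No measurement at hand accounts for the gap between compound 3 and the other compounds.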